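Trimethoxybenzoyl cinnamamides: expectation for compound 3

A few compounds are considered here, and "the series" means these few. Any claim that something is new, unique, unknown or untested is made for them only; others in the source may bear on it.

In a functional assay on COLO 205 cells (Homo sapiens) for cytotoxicity, read by MTT assay, with a stated time of 72 h (a lower number here means a stronger inhibitor, a higher number a weaker inhibitor), compound 1 `COc1cc(C(=O)c2cc(OC)c(OC)c(OC)c2)cc(NC(=O)/C=C/c2cc(OC)c(OC)c(OC)c2)c1OC` gives 5300 nM. Compound 2 `COc1ccc(/C=C/C(=O)Nc2cc(C(=O)c3cc(OC)c(OC)c(OC)c3)cc(OC)c2OC)cc1` carries a 4-methoxyphenyl in place of the 3,4,5-trimethoxyphenyl on the double-bonded chain carbon and in this assay gives 4800 nM. Going by the values given here, the only measured step, a 1.1-fold lower number from compound 1 to compound 2 (0.04 log units; within the scatter), shows that this exchange of the aryl group on the chain made no difference beyond the scatter. Of the two numbers in hand, compound 2 has the lower one, but its gap to compound 1 is within the scatter, so no order between the two can be drawn.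

Compound 3 `C#CCOc1cccc(/C=C/C(=O)Nc2cc(C(=O)c3cc(OC)c(OC)c(OC)c3)cc(OC)c2OC)c1` has not been measured. Its change from compound 2 is 3-(propargyloxy)phenyl in place of 4-methoxyphenyl on a double-bonded chain carbon bound to a double-bonded chain carbon. Among the compounds with values here, no measured step bears directly on a propargyloxy group; the single step available, a 1.1-fold lower number from compound 1 to compound 2 (0.04 log units; within the scatter), concerns a different aryl exchange at the same place and lay within the scatter. Within the data shown here, with only that guide, the aryl group on the chain appears tolerant of variation, and the expected step in this assay is a 1.1-fold lower number from compound 2 to compound 3 (0.03 log units; within the scatter), none beyond the scatter. Compound 3 is therefore estimated at 4500 nM, with a range of 1500 nM to 14000 nM.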

Compound 3, half-maximal inhibitory concentration: 11200 nM
Compound 3: the middle estimate sits 2.5-fold (0.40 log units) below what was measured; measured number inside the range.
By their numbers in this assay, from the lowest: compounds 2 and 1 (each within the scatter of the next); then compound 3.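

In this assay, the aryl group on the double-bonded chain carbon no longer looks indifferent to exchange: 3-(propargyloxy)phenyl in place of 4-methoxyphenyl gives a 2.3-fold higher number from compound 2 to compound 3 (0.37 log units; beyond the scatter) and, in place of 3,4,5-trimethoxyphenyl, gives a 2.1-fold higher number from compound 1 to compound 3 (0.32 log units; beyond the scatter) while the exchange between the two methoxy-bearing aryl groups stayed within the scatter. Both steps are modest and run the same way, so among these three compounds compound 3 is the weakest, and compounds 1 and 2 remain inseparable. The tolerance read from the first pair therefore holds for that exchange only and does not extend to every aryl group at this place.

The change from 4-methoxyphenyl to 3-(propargyloxy)phenyl alters both the ether group and the ring number at which it stands, and the compounds shown do not separate these two parts. On these data alone, a 3-methoxyphenyl or a 4-(propargyloxy)phenyl would separate them, and whether an amine or a carboxylic acid on the phenyl would be tolerated at this place remains open. No supporting evidence bears on this result.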